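The source may report more compounds than this note shows. Statements on the series, on what has been measured and on what is new or still open speak of the compounds shown alone.

Series notes. Three analogues sharing the core of compound 3 have been measured in an assay (Rattus norvegicus) for inhibition of Fatty-acid amide hydrolase 1 (Homo sapiens); a lower number here means a stronger inhibitor, a higher number a weaker inhibitor. Compound 1 `NS(=O)(=O)c1ccccc1-c1cnc(C(=O)CCCCCCc2ccccc2)o1` gives 1500 nM, compound 2 `COC(=O)c1cccc(-c2cnc(C(=O)CCCCCCc3ccccc3)o2)c1` gives 12 nM, and compound 3 `O=C(CCCCCCc1ccccc1)c1ncc(-c2ccc(F)cc2)o1` gives 62 nM. Compound 3 thus holds the second highest number of the three: compound 2 sits lower, beyond the scatter, while compound 1 sits higher, also beyond the scatter. Compound 4 `O=C(CCCCCCc1ccccc1)c1ncc(-c2cncnc2)o1` is not yet measured; its change from compound 3 is pyrimidin-5-yl in place of 4-fluorophenyl on an aromatic carbon. Going by the values given here, no measured pair isolates this change, so its effect is open. The expected step is a 1.6-fold lower number from compound 3 to compound 4 (0.19 log units; within the scatter), modest and toward a lower number, not clearly beyond the scatter. For compound 4 the estimate in this assay is 40 nM, within 10 nM to 150 nM.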

Compound 4, inhibition constant: 22 nM
Beside the measured number, compound 4's estimate is 1.8-fold (0.26 log units) above it; low and high end bracket the measured number.
By their numbers in this assay, from the lowest: compounds 2 and 4 (each within the scatter of the next); then compound 3; then compound 1.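

At this position, on an aromatic carbon next to the ring oxygen, pyrimidin-5-yl in place of 4-fluorophenyl gives a 2.8-fold lower number from compound 3 to compound 4 (0.45 log units; beyond the scatter) in this assay. This pair isolates the change and shows that a ring with 2 hetero atoms is accepted here in place of a ring of carbon only, with inhibition improved rather than lost. No measurement at hand accounts for the step. Going by these compounds, whether the ring nitrogens or the absence of fluorine drives it stays open; plain phenyl or pyridin-3-yl at this position would separate the two.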